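Replacing morpholin-4-yl on the thiocarbonyl carbon

This account rests on a few compounds, and the source may have more. Where it says the series, first, only, none or still open, it means among the compounds named here.

Within the data shown here, in a functional assay on A549 cells (Homo sapiens) for antiproliferative activity, read by MTT assay, with a stated time of 48 h (a higher number here means a weaker inhibitor, a lower number a stronger inhibitor), two compounds have measured numbers so far. Compound 1 (`O=C(Nc1ccc([N+](=O)[O-])cc1)Nc1cccc(NC(=O)c2ccccn2)c1`) gives 320 nM, and compound 2 (`O=C(CSC(=S)N1CCOCC1)Nc1cccc(NC(=O)c2ccccn2)c1`) gives 50 nM. Compound 2 therefore holds the lower of the two numbers, and the gap lies beyond the usual scatter of repeated measurements.

The next structure is compound 3 (`C=CCN1CCN(C(=S)SCC(=O)Nc2cccc(NC(=O)c3ccccn3)c2)CC1`), which has 4-allylpiperazin-1-yl in place of morpholin-4-yl on a thiocarbonyl carbon. The rest of the structure is unchanged. Among the measured compounds shown here, no measured pair shows a change at this place, so the data give no direct guide to the size of the step. The expectation is anchored on compound 2 at 50 nM, since both groups are six-membered non-aromatic rings. From the compounds shown here alone, the expected change is a 1.2-fold higher number from compound 2 to compound 3 (0.08 log units; within the scatter) in this assay, a step not expected to go beyond the scatter, although a larger move in either direction remains open. For compound 3 the estimated value is 60 nM, with an expected range of 15 nM to 240 nM.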

Compound 3, half-maximal inhibitory concentration: 210 nM
Estimate against measurement, compound 3: 3.5-fold (0.54 log units) below; low and high end bracket the measured number.
By their numbers in this assay, from the lowest: compound 2; then compounds 3 and 1 (each within the scatter of the next).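

In this assay, the first change read at this place, on a thiocarbonyl carbon, is 4-allylpiperazin-1-yl in place of morpholin-4-yl, and it gives a 4.2-fold higher number from compound 2 to compound 3 (0.62 log units; beyond the scatter). The number at this place therefore responds to the group carried there, even though both groups are one six-membered non-aromatic ring with 2 hetero atoms and have the same counts of hydrogen-bond donors and acceptors. Those shared features do not hold the number in place, but nothing measured here explains the step, which also bundles together more heavy atoms, a ring nitrogen in place of the ring oxygen and a double bond outside aromatic rings.

The compounds shown leave open which of these differences carries the step, a question that 4-methylpiperazin-1-yl or piperidin-1-yl at this place would help to separate. Also open, from the compounds shown here alone, is whether an open-chain group such as diethylamino on the thiocarbonyl carbon would stay close to compound 2 at 50 nM or move as far as the allylpiperazine did.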